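Aryl exchange from compound 2 to compound 3

A few compounds are considered here, and "the series" means these few. Any claim that something is new, unique, unknown or untested is made for them only; others in the source may bear on it.

In a functional assay on HL-60 cells (Homo sapiens) for antiproliferative activity, read by MTT assay, with a stated time of 72 h (on this read-out lower numbers stand for stronger inhibition and higher numbers for weaker inhibition), compound 2 `NC1=NC2(CCOCC2)N(OCCCOc2ccccc2Br)C(N)=N1` gives 610 nM and compound 1 `Cc1cc(C)cc(OCCCON2C(N)=NC(N)=NC23CCOCC3)c1` gives 720 nM, so the two stand level within the scatter. Compound 3 `Cc1ccc(OCCCON2C(N)=NC(N)=NC23CCOCC3)cc1` is next: 4-methylphenyl in place of 2-bromophenyl on an oxygen on a saturated carbon. Within the data shown here, the only measured step bearing on this is a 1.2-fold lower number from compound 1 to compound 2 (0.07 log units; within the scatter), which also replaces the group on that oxygen. Among the measured compounds shown here, with that step as the sole guide, no step beyond the scatter is expected for compound 3 in this assay. The estimated step is a 1.1-fold higher number from compound 2 to compound 3 (0.03 log units; within the scatter). For compound 3 the expected value is 650 nM, with an estimated range of 300 nM to 1400 nM.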

Compound 3, half-maximal inhibitory concentration: 2580 nM
Compound 3: the middle estimate sits 4.0-fold (0.60 log units) below what was measured, outside the stated range (above it).
By their numbers in this assay, from the lowest: compounds 2 and 1 (each within the scatter of the next); then compound 3.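

The group on this oxygen is not freely exchangeable: in this assay, 4-methylphenyl gives a 4.2-fold higher number from compound 2 to compound 3 (0.63 log units; beyond the scatter) and a 3.6-fold higher number from compound 1 to compound 3 (0.55 log units; beyond the scatter), although 2-bromophenyl and 3,5-dimethylphenyl stand level within the scatter. Methyl groups on the ring do not settle the outcome, since compound 1 and compound 3 both carry them. Nothing measured here accounts for this rise. Still open, as far as these compounds go, is whether 4-bromophenyl would stay level with compound 2 or rise like compound 3, and how a phenyl ring bearing an amine or a carboxylic acid would read here.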